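The source may hold more compounds than are shown below. What is called first, only, known or untested is meant among the compounds shown, and "the series" means these compounds.

Measured compounds in an ADME assay on microsomes from liver (Homo sapiens) for metabolic stability, read by LC-MS, using NADPH, with a stated time of 60 min, tested at 1 uM; a lower number here means slower removal, a higher number faster removal of the compound:
compound 1 `CCC(Nc1ccc(S(=O)(=O)Nc2nccs2)cc1Cl)c1ccccc1` — 156 mL/min/kg
compound 2 `CC(Nc1ccc(S(=O)(=O)Nc2nccs2)cc1Cl)c1ccccc1` — 81 mL/min/kg
compound 3 `C[C@H](Nc1cc(F)c(S(=O)(=O)Nc2cscn2)cc1Cl)c1cc(CN2CCC2)ccc1F` — 19 mL/min/kg

Compound 1 and compound 2 share a core and differ only by hydrogen in place of methyl on a saturated chain carbon, two bonds along the chain from an aromatic carbon and a nitrogen on an aromatic ring. The resulting step, a 1.9-fold lower number from compound 1 to compound 2 (0.28 log units; within the scatter), does not leave the usual scatter, so the two numbers are treated as indistinguishable. Compound 3 carries a different core; how that core differs from the core of compound 1 is not broken down here. Its number is the lowest of the three, and its separation from compound 2 and from compound 1 lies beyond the scatter in both cases.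

Compound 4 `O=S(=O)(Nc1cscn1)c1cc(Cl)c(NCc2cc(CN3CCC3)ccc2F)cc1F` has not yet been measured. It differs from compound 3 by hydrogen in place of methyl on a saturated chain carbon bound to an aromatic carbon and a nitrogen on an aromatic ring. This is the same kind of change as that from compound 1 to compound 2, though not the same: in the earlier pair the saturated chain carbon is two bonds along the chain from an aromatic carbon and a nitrogen on an aromatic ring, whereas in compound 3 it is bound to an aromatic carbon and a nitrogen on an aromatic ring. Because a 1.9-fold lower number from compound 1 to compound 2 (0.28 log units; within the scatter) stays within the scatter, a small step is likewise expected here: a 1.1-fold lower number from compound 3 to compound 4 (0.05 log units; within the scatter). The expectation rests on that single earlier pair and on the value of compound 3, 19 mL/min/kg, as the starting point. Compound 4 is therefore expected to give about 17 mL/min/kg, with a likely range from 8 mL/min/kg to 36 mL/min/kg.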

Compound 4, clearance: 12 mL/min/kg
Compound 4: middle estimate off by 1.4-fold (0.15 log units), on the high side; the range from low to high includes it.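

In this assay, hydrogen in place of methyl on a saturated chain carbon bound to an aromatic carbon and a nitrogen on an aromatic ring gives a 1.6-fold lower number from compound 3 to compound 4 (0.20 log units; within the scatter), so the two numbers count as indistinguishable. Set beside the earlier pair, the change reads alike on the two cores, with no difference between the steps that can be told apart: the same change on two cores in this assay, a 1.9-fold lower number (0.28 log units; within the scatter) from compound 1 to compound 2 and a 1.6-fold lower number (0.20 log units; within the scatter) from compound 3 to compound 4, 1.2-fold (0.09 log units) apart, within the scatter of two such steps Within this series, the exchange of methyl for hydrogen has so far carried from one core to the other without a step beyond the scatter, but two pairs show neither that the exchange itself moves clearance in either direction nor that the same result would hold on a third core, and the place of the change is also not identical in the two pairs.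

The compounds shown leave open how a hydroxymethyl group or a cyclopropyl group on that saturated chain carbon would read in this assay on the core of compound 3. They also leave open which of the differences between the core of compound 1 and the core of compound 3 goes with the gap between those two compounds.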